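Adding 4-bromobenzyl to an amide-type nitrogen

The source may hold more compounds than are shown below. What is called first, only, known or untested is meant among the compounds shown, and "the series" means these compounds.

In a functional assay on PC-3 cells (Homo sapiens) for inhibition, read by WST assay, with a stated time of 48 h (on this read-out lower numbers stand for stronger inhibition of growth and higher numbers for weaker inhibition of growth), compound 3 (`C=C(C)C(=O)NC(=O)/C=C/c1cc(OC)c(OC)c(OC)c1`) gives 8200 nM as its measured value. Compound 2 (`C#CCN(C(=O)/C=C/c1cc(OC)c(OC)c(OC)c1)C(=O)C(=C)C`) gives 7300 nM and the two cannot be told apart, the step being a 1.1-fold higher number from compound 2 to compound 3 (0.05 log units; within the scatter) and nothing more. Compound 1 (`C=C(C)C(=O)N(C)C(=O)/C=C/c1cc(OC)c(OC)c(OC)c1`) gives > 10000 nM and that is a limit, not a number.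

Compound 4 (`C=C(C)C(=O)N(Cc1ccc(Br)cc1)C(=O)/C=C/c1cc(OC)c(OC)c(OC)c1`) differs from compound 3 by 4-bromobenzyl in place of hydrogen on an amide-type nitrogen. The other measured steps also change the group at that nitrogen. They are an at least 1.2-fold lower number from compound 1 to compound 3 (0.08 log units; that floor lies within the scatter) and an at least 1.3-fold lower number from compound 1 to compound 2 (0.13 log units; that floor lies within the scatter) and both are only floors. Together with the propargyl step, they show no shift beyond the scatter. None of these groups holds an aromatic ring, however, so they are a loose guide for this change. The change expected is therefore small, with an estimated 1.5-fold lower number from compound 3 to compound 4 (0.17 log units; within the scatter) as the likely outcome. For compound 4 the expected value is 5500 nM with an estimated range from 2000 nM to 10000 nM as the likely span.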

Compound 4, concentration for 50% growth inhibition: > 10000 nM
Compound 4: only a limit was reported; the forecaster's own chance of this, stated with the estimate: 15%; middle value at least 1.8-fold (0.25 log units) away from the limit.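

The 4-bromobenzyl group puts an aromatic ring on the amide-type nitrogen, the only such group at this position among the compounds shown, and in this assay compound 4 gives > 10000 nM, which is a limit and not a number. The readable steps are an at least 1.2-fold higher number from compound 3 to compound 4 (0.08 log units; that floor lies within the scatter) and an at least 1.3-fold higher number from compound 2 to compound 4 (0.13 log units; that floor lies within the scatter), so this group shows no gain in growth inhibition and no proven loss. The step between compound 1 and compound 4 cannot be read, and the end of the assay's range now restricts what can be said about this nitrogen: the limit of > 10000 nM in this assay, at which 2 of the 4 values shown sit.

Going by these compounds, the true value of compound 4 remains open. So does whether a plain benzyl group without bromine, or a benzyl group carrying an amine or a carboxylic acid, would read differently at this nitrogen.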